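Inverting two ring stereocentres of an inactive cyclic peptide

The source may hold more compounds than are shown below. What is called first, only, known or untested is meant among the compounds shown, and "the series" means these compounds.

Compound 1 `N=C(N)NCCC[C@@H]1NC(=O)CC(=O)N[C@@H](CC(=O)O)C(=O)N[C@H](Cc2ccccc2)CNC1=O`: 24 nM in an assay on K562 cells for inhibition of integrin alpha-5/beta-1 (Homo sapiens), with a stated time of 30 min; a higher number here means a weaker inhibitor, a lower number a stronger inhibitor.
Compound 2 `N=C(N)NCCC[C@H]1NC(=O)CC(=O)N[C@H](CC(=O)O)C(=O)N[C@@H](Cc2ccccc2)CNC1=O`: > 100000 nM, which is a limit of this assay and not a number.

Compound 2 thus sits at the limit beyond which this assay reports nothing (the limit of > 100000 nM in this assay, at which 1 of the 2 values shown sits). Compound 3 `N=C(N)NCCC[C@@H]1NC(=O)CC(=O)N[C@H](CC(=O)O)C(=O)N[C@H](Cc2ccccc2)CNC1=O` differs from it only in stereochemistry: the two compounds have the same atoms and bonds; at least one stereo element is drawn with a configuration in one of them and without one in the other: 2 of 4 stereo elements differ; a stereocentre at a saturated ring carbon is drawn R in compound 2 and S in compound 3; a stereocentre at a saturated ring carbon is drawn S in compound 2 and R in compound 3. Going by the values given here, the single measured step, an at least 4100-fold higher number from compound 1 to compound 2 (3.61 log units; beyond the scatter), inverted three stereocentres; the present change reverses two of those three inversions, so a large fall in the number is expected, though not necessarily all the way back. Compound 3 is estimated at 5000 nM (range 300 nM to 100000 nM), which is an expected step of an at least 20-fold lower number from compound 2 to compound 3 (1.30 log units; beyond the scatter).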

Compound 3, half-maximal inhibitory concentration: 1300 nM
Compound 3: middle estimate off by 3.8-fold (0.59 log units), on the high side; the measured number falls inside the stated range.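

Inverting two stereocentres back brings binding into the measurable range of this assay, with an at least 76-fold lower number from compound 2 to compound 3 (1.88 log units; beyond the scatter) and with the value of compound 2 being a limit of the assay and not a number. The recovery is only partial: a single stereocentre at a saturated ring carbon accounts for a 54-fold higher number from compound 1 to compound 3 (1.73 log units; beyond the scatter) on its own, so one inversion is enough for a large loss.

Still open, going by these compounds, is how each of the other two inversions acts alone, and whether a longer chain carrying the carboxylic acid would respond in the same way. Nothing shown gives a reason for the size of these steps.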